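The source may hold more compounds than are shown below. What is called first, only, known or untested is meant among the compounds shown, and "the series" means these compounds.

Measured so far:
- compound 1, `Fc1ccccc1Nc1nc(-c2ccccn2)cs1`; in an ADME assay on microsomes from liver (Mus musculus) for metabolic stability, read by LC-MS, using NADPH (on this read-out higher numbers stand for a longer-lived compound and lower numbers for a shorter-lived compound), compound 1 sits at the limit < 0.0167 h
- compound 2, `COC(=O)c1cccc(-c2cnc(Nc3cccc(F)c3)o2)c1`; in this assay compound 2 sits at the limit < 0.0167 h
- compound 3, `COC(=O)c1cccc(-c2cnc(Nc3ccc(F)cc3)o2)c1`; in this assay compound 3 gives 0.0183 h

Compound 3 holds the only half-life that is given as a number; the other two values are limits of the assay rather than numbers, and the limit of < 0.0167 h in this assay, at which 2 of the 3 values shown sit, marks where they sit. For the measured compounds named here, the one step computed among the measured compounds is an at least 1.0-fold higher number from compound 2 to compound 3 (0.03 log units; that floor lies within the scatter), which moves from a limit to a number close to it and lies within the scatter.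

Compound 4, `CNC(=O)c1cccc(-c2cnc(Nc3ccc(F)cc3)o2)c1`, differs from compound 3 in one place: methylamino in place of methoxy on a carbonyl carbon. Going by the values given here, none of the measured steps touches this part of the molecule; the only step in hand, an at least 1.0-fold higher number from compound 2 to compound 3 (0.03 log units; that floor lies within the scatter), concerns the fluorophenyl on the ring nitrogen, and the limit values of compound 1 and compound 2 give no direction. There is therefore no measured basis for expecting a step beyond the scatter in this assay from compound 3 to compound 4.

Compound 4 is accordingly expected to give about 0.025 h in this assay, between 0.0167 h and 0.08 h. The step from compound 3 to compound 4 is expected to be a 1.4-fold higher number from compound 3 to compound 4 (0.14 log units; within the scatter), within the scatter.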

Compound 4, half-life: 0.025 h
Compound 4: the middle estimate sits on the measured number at the digits printed, within the range that was stated.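

In this assay, the first change shown at this position, methylamino in place of methoxy on a carbonyl carbon, gives a 1.4-fold higher number from compound 3 to compound 4 (0.14 log units; within the scatter). Unlike the earlier step, which starts from a limit, this one has a number at both ends, so it is the first direct reading of methoxycarbonyl to methylcarbamoyl on this scaffold, and it shows that the exchange, which adds a hydrogen-bond donor and removes a hydrogen-bond acceptor at this place, does not shift the half-life beyond the scatter. The half-lives of compound 3 and compound 4 therefore read as one level, and the limit of the read-out remains close to that level: the limit of < 0.0167 h in this assay, at which 2 of the 4 values shown sit.

The compounds shown leave open whether another group on this carbonyl carbon, such as dimethylamino, the hydroxyl of a carboxylic acid, or a longer chain on the amide nitrogen, would take the half-life beyond the scatter. They also leave open whether the step from methoxy to methylamino would read the same with the 3-fluorophenyl group of compound 2 in place of the 4-fluorophenyl group.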